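Cytotoxicity of aryl-substituted naphthoquinone sulfonylamidines

The source may hold more compounds than are shown below. What is called first, only, known or untested is meant among the compounds shown, and "the series" means these compounds.

Measured compounds:
compound 1 `Cc1ccc(S(=O)(=O)/N=C(/CCNC2=CC(=O)c3ccccc3C2=O)Nc2ccc(Cl)cc2)cc1` gives 65400 nM
compound 2 `Cc1ccc(S(=O)(=O)/N=C(/CCNC2=CC(=O)c3ccccc3C2=O)Nc2ccccc2I)cc1` gives 49400 nM

Both numbers come from an ADME assay on HEK293 cells (Homo sapiens) for cytotoxicity, read by MTT assay, with a stated time of 48 h; a lower number here means a stronger inhibitor, a higher number a weaker inhibitor. Compound 2 shows the lowest of the two numbers, but its neighbour is compound 1, and the step of a 1.3-fold lower number from compound 1 to compound 2 (0.12 log units; within the scatter) lies within the scatter, so the two compounds cannot be told apart on these numbers.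

Compound 3 `Cc1ccc(S(=O)(=O)/N=C(/CCNC2=CC(=O)c3ccccc3C2=O)Nc2cccc(C)c2)cc1` has not been measured in this assay. It differs from compound 2 in one place: 3-methylphenyl in place of 2-iodophenyl on an amine nitrogen. Going by the values given here, the only measured step that bears on this change is the one from compound 1 to compound 2, where one aryl group on the amine nitrogen was swapped for another and the number moved a 1.3-fold lower number from compound 1 to compound 2 (0.12 log units; within the scatter), within the scatter. A further swap of the aryl group at the same place therefore carries no sign that the number should move beyond the scatter in either direction. For compound 3 the expected step is a 1.1-fold higher number from compound 2 to compound 3 (0.05 log units; within the scatter), within the scatter. Compound 3 is estimated to give 55000 nM in this assay, with a range from 20000 nM to 150000 nM.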

Compound 3, half-maximal inhibitory concentration: 56200 nM
Beside the measured number, compound 3's estimate is 1.0-fold (0.01 log units) below it; the range from low to high includes it.
By their numbers in this assay, from the lowest: compounds 2, 3 and 1 (each within the scatter of the next).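

In this assay, the earlier pair held only halogen-bearing rings on the amine nitrogen, so it could not say whether a halogen on that ring matters. Compound 3 carries a methyl instead, and the step is a 1.1-fold higher number from compound 2 to compound 3 (0.06 log units; within the scatter) against the iodine-bearing ring, while it is a 1.2-fold lower number from compound 1 to compound 3 (0.07 log units; within the scatter) against the chlorine-bearing ring. The 3-methylphenyl, 2-iodophenyl and 4-chlorophenyl groups therefore cannot be told apart here, and on these three compounds the number does not depend on whether this ring carries a halogen or a methyl.

All three groups are still six-membered aromatic rings of carbon only, so the compounds shown leave open whether the same holds for a different kind of group on this nitrogen, such as a pyridine ring, a saturated cyclohexyl ring or a longer alkyl chain. They also leave open whether a ring carrying a carboxylic acid or an amine would stay within the scatter of these three, or whether the numbers would shift away from this narrow cluster. No supporting measurement is available to explain why these three numbers lie so close together.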